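The source may hold more compounds than are shown below. What is called first, only, known or untested is meant among the compounds shown, and "the series" means these compounds.

Measured compounds:
compound 1, `Cc1cc(C)cc(NC(=O)CN2CCC(c3cccc[n+]3[O-])CC2)c1`: 52 nM
compound 2, `C=Cc1cccc(C(=O)NCN2CCC(c3cccc[n+]3[O-])CC2)c1`: 68 nM
compound 3, `O=C(NCN1CCC(c2cccc[n+]2[O-])CC1)c1ccc2ccccc2c1`: 115 nM

In a functional assay on HEK293 cells for agonist activity at D(4) dopamine receptor (Homo sapiens), read by FLIPR (a higher number here means that more compound is needed for the effect, a lower number that less compound is needed), compound 1 gives the lowest of the three numbers; compound 2 sits within the scatter of it, while compound 3 gives a number beyond the scatter of compound 1. Compound 4, `CSc1cccc(NC(=O)CN2CCC(c3cccc[n+]3[O-])CC2)c1`, differs from compound 1 in one place: 3-(methylsulfanyl)phenyl in place of 3,5-dimethylphenyl on an amide-type nitrogen. Going by the values given here, no pair of measured compounds isolates this change, so its size is not known from the series itself. The expectation for the step from compound 1 to compound 4 is a small one, a 1.5-fold higher number from compound 1 to compound 4 (0.19 log units; within the scatter), possibly none beyond the scatter, with a slight lean toward a higher number. Compound 4 is accordingly estimated at 80 nM, within a range of 30 nM to 220 nM.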

Compound 4, half-maximal effective concentration: 100 nM
Compound 4: the middle estimate sits 1.3-fold (0.10 log units) below what was measured; low and high end bracket the measured number.
By their numbers in this assay, from the lowest: compounds 1, 2, 4 and 3 (each within the scatter of the next, the first and the last beyond it).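

On the amide-type nitrogen, 3-(methylsulfanyl)phenyl can replace 3,5-dimethylphenyl with only a modest shift in this assay: a 1.9-fold higher number from compound 1 to compound 4 (0.28 log units; within the scatter). Going by these compounds alone, this is the first single-place step, and it shows that bringing in a sulfur and a hydrogen-bond acceptor at the same heavy-atom count does not move the number beyond the scatter. Nothing shown accounts for the size of this step. Open, going by these compounds, is whether an amine or a carboxylic acid on the phenyl ring would keep this assay in this range. On these data alone, the effect of the amide linkage alone also remains open, since compound 2 and compound 3 differ from compound 1 in more than one place.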